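Propyl in place of 3-fluorophenyl on an amide-type nitrogen

A few compounds are considered here, and "the series" means these few. Any claim that something is new, unique, unknown or untested is made for them only; others in the source may bear on it.

In a functional assay on A2780 cells (Homo sapiens) for antiproliferative activity, read by fluorescence, with a stated time of 72 h (a higher number here means a weaker inhibitor, a lower number a stronger inhibitor), compound 1 (`CN1CCC(C(=O)N2Cc3c(NC(=O)c4cc(F)cc(F)c4)n[nH]c3C2(C)C)CC1`) gives 130 nM and compound 2 (`CN1CCC(C(=O)N2Cc3c(NC(=O)Nc4cccc(F)c4)n[nH]c3C2(C)C)CC1`) gives 350 nM, the higher of the two numbers. Going by the values given here, the only measured step, a 2.7-fold higher number from compound 1 to compound 2 (0.43 log units; beyond the scatter), is modest and puts (3-fluorophenyl)amino in place of 3,5-difluorophenyl on a carbonyl carbon. Compound 3 (`CCCNC(=O)Nc1n[nH]c2c1CN(C(=O)C1CCN(C)CC1)C2(C)C`) carries propyl in place of 3-fluorophenyl on an amide-type nitrogen. Among the compounds with values here, no measured step makes this exact change, so that modest step is only a loose guide. The expected change in this assay is a modest upward one, an estimated 2.9-fold higher number from compound 2 to compound 3 (0.46 log units; beyond the scatter). For compound 3 the expected value is 1000 nM, with an estimated range of 300 nM to 4000 nM.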

Compound 3, half-maximal inhibitory concentration: 650 nM
Compound 3: middle estimate off by 1.5-fold (0.19 log units), on the high side, and the stated range covers the measured number.
By their numbers in this assay, from the lowest: compound 1; then compounds 2 and 3 (each within the scatter of the next).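

In this assay the step of a 1.9-fold higher number from compound 2 to compound 3 (0.27 log units; within the scatter) shows that propyl can stand in place of 3-fluorophenyl on this amide-type nitrogen, so a six-membered aromatic ring of carbon only is not required there for a number of this size. The larger step of a 5.0-fold higher number from compound 1 to compound 3 (0.70 log units; beyond the scatter) is modest and puts propylamino in place of 3,5-difluorophenyl on a carbonyl carbon. On these data alone, whether a longer chain such as hexyl, or a cyclohexyl ring, on this nitrogen would give a similar number remains open. No measured evidence accounts for either step.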